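The source may hold more compounds than are shown below. What is called first, only, known or untested is meant among the compounds shown, and "the series" means these compounds.

Working notes on the series. In an assay on CHO cells with Alpha-2C adrenergic receptor (Homo sapiens) as the target (a lower number here means a smaller maximal response, a higher number a larger maximal response), compound 3 `CC(Oc1ccccc1S(C)(=O)=O)C1=NCCN1` gives 0.6, while compound 2 `COc1ccccc1OC(C)C1=NCCN1` gives 0.6; no change at the digits printed from compound 2 to compound 3 (within the scatter). Compound 1 `C=COc1ccccc1OC(C)C1=NCCN1` gives 0.48, so that a number 0.12 higher from compound 1 to compound 3 (beyond the scatter) and a number 0.12 higher from compound 1 to compound 2 (beyond the scatter). Compound 3 therefore stands level with compound 2, the two together at the top of the three numbers, with compound 1 furthest off.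

Compound 4 `C=C(C)c1ccccc1OC(C)C1=NCCN1` is not yet measured. Its change from compound 3 is 1-methylethenyl in place of methylsulfonyl on an aromatic carbon. Among the measured compounds shown here, the steps that bear on it are no change at the digits printed from compound 2 to compound 3 (within the scatter) and a number 0.12 higher from compound 1 to compound 3 (beyond the scatter): exchanging the group on this aromatic carbon has moved the figure modestly at most. A modest fall is expected, a number 0.10 lower from compound 3 to compound 4 (within the scatter), because compound 1, carrying vinyloxy at that carbon, gives 0.48. Compound 4 is estimated at 0.5, within 0.35 to 0.65.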

Compound 4, intrinsic activity: the largest response reached, as a fraction of the reference agonist's: 0.71
Compound 4: middle estimate off by 0.21, on the low side; the measured number lies above the stated range.
By their numbers in this assay, from the lowest: compound 1; then compounds 2 and 3 (each within the scatter of the next); then compound 4.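

In this assay, 1-methylethenyl on this aromatic carbon gives a number 0.11 higher from compound 3 to compound 4 (beyond the scatter) and a number 0.11 higher from compound 2 to compound 4 (beyond the scatter), so the level shared by the methylsulfonyl and methoxy compounds is not the ceiling for this position. The largest step in the series is a number 0.23 higher from compound 1 to compound 4 (beyond the scatter). Vinyloxy and 1-methylethenyl both carry a carbon-carbon double bond yet mark the two ends of the order, so that bond alone does not set the figure.

No measurement available here accounts for these steps. As far as these compounds go, whether isopropyl, the saturated counterpart of 1-methylethenyl, or an amine on this carbon would hold the maximal response remains open.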